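The source may hold more compounds than are shown below. What is called first, only, known or untested is meant among the compounds shown, and "the series" means these compounds.

Measured so far in an ADME assay on L929 cells (Mus musculus, culture collection number NCTC 929) for cytotoxicity, read by MTT assay, with a stated time of 72 h; a lower number here means a stronger inhibitor, a higher number a weaker inhibitor:
Compound 1 `CCCCCCCCc1c(O)cc(C)oc1=O`: 145000 nM
Compound 2 `Cc1cc(O)c(C(=O)CCC2CCCCC2)c(=O)o1`: 117000 nM

In this assay, compound 2 stands at 117000 nM. Among the measured compounds shown here, that number lies within the usual scatter of the one for compound 1, so the two cannot be told apart on these data.

Compound 3 `CCCCCCCC(=O)c1c(O)cc(C)oc1=O` has not yet been measured. It differs from compound 2 by having pentyl in place of cyclohexyl on a saturated chain carbon, two bonds along the chain from a carbonyl carbon.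

For the measured compounds named here, no measured pair differs in only one place, so no direct precedent exists for this change. The side chains of compound 1 and compound 2 differ, yet their values stay within the scatter, so no step beyond the scatter is expected in this assay. The expected change is a 1.1-fold higher number from compound 2 to compound 3 (0.05 log units; within the scatter). For compound 3 the estimated value is 130000 nM, with an expected range from 70000 nM to 240000 nM.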

Compound 3, half-maximal inhibitory concentration: 140000 nM
For compound 3 the middle estimate is 1.1-fold (0.03 log units) below the measured one; the measured number falls inside the stated range.
By their numbers in this assay, from the lowest: compounds 2, 3 and 1 (each within the scatter of the next).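

In this assay, putting pentyl in place of cyclohexyl on a saturated chain carbon, two bonds along the chain from a carbonyl carbon, gives a 1.2-fold higher number from compound 2 to compound 3 (0.08 log units; within the scatter) and so leaves the two compounds indistinguishable. Among the compounds shown here, this is the first direct comparison at this position, and it shows that opening up the ring-bearing end into a plain chain produces no readable change in this cell assay. Nothing measured here bears on the reason for this result.

Cyclohexyl and pentyl are both built only of carbon and hydrogen, so the compounds shown cover only a narrow range of groups at this place. Going by these compounds, an amine, a carboxylic acid or a phenyl ring could still move the number beyond the scatter, and whether any of them would remains open.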